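Para substituent scan on the shared anilino core

This account rests on a few compounds, and the source may have more. Where it says the series, first, only, none or still open, it means among the compounds named here.

Measured in a functional assay on PANC-1 cells (Homo sapiens) for cytotoxicity, read by MTT assay, with a stated time of 72 h; on this read-out higher numbers stand for weaker inhibition and lower numbers for stronger inhibition:
- compound 1 `Nc1ccc(-c2ccc(NC3=CC(=O)c4ncncc4C3=O)cc2)cc1`: 3700 nM
- compound 2 `NC(=O)c1ccc(NC2=CC(=O)c3ncncc3C2=O)cc1`: 6300 nM
- compound 3 `CCOC(=O)c1ccc(NC2=CC(=O)c3ncncc3C2=O)cc1`: 1600 nM

Compound 3 gives the lowest number of the three. The step of a 2.3-fold lower number from compound 1 to compound 3 (0.36 log units; beyond the scatter) and the step of a 3.9-fold lower number from compound 2 to compound 3 (0.60 log units; beyond the scatter) both lead to it, and both are beyond the scatter; the step of a 1.7-fold higher number from compound 1 to compound 2 (0.23 log units; within the scatter) is within it.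

Compound 4 `O=C1C(Nc2ccc(Oc3ccccc3)cc2)=CC(=O)c2ncncc21` differs from compound 3 by phenoxy in place of ethoxycarbonyl on an aromatic carbon. Among the measured compounds shown here, no measured step swaps ethoxycarbonyl for phenoxy. What comes closest is the comparison of compound 1, which carries an aromatic ring at this position, with compound 3, which carries the ester: that step, a 2.3-fold lower number from compound 1 to compound 3 (0.36 log units; beyond the scatter), favours the ester. Phenoxy brings back an aromatic ring and removes the carbonyl that compound 3 shares with compound 2, so compound 4 is expected to land nearer compound 1 than compound 3.

For compound 4 the estimate in this assay is 3000 nM, with a range of 1000 nM to 9000 nM, meaning an expected step of a 1.9-fold higher number from compound 3 to compound 4 (0.27 log units; within the scatter).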

Compound 4, half-maximal inhibitory concentration: 1800 nM
For compound 4 the middle estimate is 1.7-fold (0.22 log units) above the measured one; the measured number falls inside the stated range.
By their numbers in this assay, from the lowest: compounds 3 and 4 (each within the scatter of the next); then compounds 1 and 2 (each within the scatter of the next).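

Replacing ethoxycarbonyl with phenoxy gives a 1.1-fold higher number from compound 3 to compound 4 (0.05 log units; within the scatter), so in this assay a low number at this position does not depend on a carbonyl in the substituent, and two structurally different groups give values within the scatter of each other. Phenoxy also compares well with the other two groups, with a 3.5-fold lower number from compound 2 to compound 4 (0.54 log units; beyond the scatter) and a 2.1-fold lower number from compound 1 to compound 4 (0.31 log units; beyond the scatter), so an aromatic ring in the substituent does not by itself go with the higher number seen for compound 1. No available data bear on the reason for these differences.

Open questions are whether the oxygen of phenoxy matters, which a benzyl or phenylamino group would test, and whether the ethoxy part of the ester matters, which a carboxylic acid would test. With a single cell line shown, the selectivity of these compounds also remains open.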